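Methyl for methoxy across two aryl triazoles

This account rests on a few compounds, and the source may have more. Where it says the series, first, only, none or still open, it means among the compounds named here.

Compound 1 `Cc1ccc(-c2n[nH]c(-c3ccccc3)n2)c(C)c1` gives 0.2 mg/kg in a functional assay on the whole organism (Cricetulus griseus) with Cricetinae gen. sp. as the target; a higher number here means that more compound is needed for the effect, a lower number that less compound is needed. Compound 2 `COc1ccc(-c2n[nH]c(-c3ccccc3)n2)c(C)c1` reaches only a limit in this assay, > 10 mg/kg (the limit of > 10 mg/kg in this assay, at which 1 of the 3 values shown sits). Compound 3 `COc1ccccc1-c1n[nH]c(-c2ccccc2C)n1` gives 0.5 mg/kg in this assay, the highest of the two numbers that are not limits; set against compound 1, its value is higher by an amount outside the usual scatter.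

The change from compound 2 to compound 1, (methyl in place of methoxy on an aromatic carbon), brought an at least 50-fold lower number from compound 2 to compound 1 (1.69 log units; beyond the scatter). Compound 4 `Cc1ccccc1-c1n[nH]c(-c2ccccc2C)n1` arises from compound 3 by the same kind of change, (methyl in place of methoxy on an aromatic carbon). The places are not identical: in compound 2 the methoxy sits meta to a methyl group and para to a large group, in compound 3 it sits ortho to a large group. The difference between the cores of compound 3 and compound 2 is not broken down here.

For compound 4 a lower number than for compound 3 is expected, a step of a 2.5-fold lower number from compound 3 to compound 4 (0.40 log units; beyond the scatter), which rests on an at least 50-fold lower number from compound 2 to compound 1 (1.69 log units; beyond the scatter) but is taken as smaller because compound 3 already gives 0.5 mg/kg. Compound 4 is estimated at 0.2 mg/kg, expected between 0.05 mg/kg and 0.8 mg/kg.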

Compound 4, dose for half-maximal effect: 0.7 mg/kg
For compound 4 the middle estimate is 3.5-fold (0.54 log units) below the measured one; low and high end bracket the measured number.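

Methyl in place of methoxy does not carry over in size from one core to the other in this assay: the same change on two cores in this assay, an at least 50-fold lower number (1.69 log units; beyond the scatter) from compound 2 to compound 1 and a 1.4-fold higher number (0.15 log units; within the scatter) from compound 3 to compound 4, at least 70-fold (1.84 log units) apart, beyond the scatter of two such steps. On the core of compound 3, with the group ortho to a large group, the change gives a 1.4-fold higher number from compound 3 to compound 4 (0.15 log units; within the scatter), so compound 3 and compound 4 cannot be told apart in this read-out. Compound 2 gives only a limit, > 10 mg/kg, and the two pairs differ both in the core and in where the methoxy sits, so the data do not show which of these two differences sets the gap, nor how large the earlier step really is.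

Among the compounds shown, only methyl and methoxy are compared at these places, so it remains open how a hydroxyl group, a chlorine atom or an amine would read in this assay on either core. Also open, going by these compounds, is whether a larger ether, such as ethoxy, would follow methoxy on the core of compound 1.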